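Aromatic replaces saturated ring on the thioether of compound 3

The source may hold more compounds than are shown below. What is called first, only, known or untested is meant among the compounds shown, and "the series" means these compounds.

Three compounds have been measured in an assay on isolated protein for binding affinity to Equilibrative nucleoside transporter 1 (Homo sapiens); a higher number here means a weaker inhibitor, a lower number a stronger inhibitor:
compound 1, `O=[N+]([O-])c1ccc2c(c1)CN(c1ncnc3c1ncn3[C@@H]1O[C@H](CO)[C@@H](O)[C@H]1O)CC2`, with 5.5 nM;
compound 2, `Nc1ncnc2c1ncn2[C@@H]1O[C@H](COCCOCCNc2ncnc3c2ncn3[C@@H]2O[C@H](CO)[C@@H](O)[C@H]2O)[C@@H](O)[C@H]1O`, with 912000 nM;
compound 3, `OC[C@H]1O[C@@H](n2cnc3c(SC4CCCCC4)ncnc32)[C@H](O)[C@@H]1O`, with 6310 nM.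

Among these three, compound 3 holds the second highest number. Its nearest neighbour is compound 2, whose number is far higher, and the gap to compound 1, whose number is far lower, is wider still; both gaps lie well beyond the scatter of this assay. Compound 3 is therefore neither the weakest nor the strongest of the set, but sits much closer in order to compound 1 than in value.

The untested compound 4, `Cc1ccc(CSc2ncnc3c2ncn3[C@@H]2O[C@H](CO)[C@@H](O)[C@H]2O)cc1`, differs from compound 3 in one place: 4-methylbenzyl in place of cyclohexyl on a sulfur. Among the measured compounds shown here, no measured pair in the set shows this exact exchange, so the size of the step has to be judged from the surrounding numbers. Compound 1 carries an aromatic ring attached through a nitrogen to the core and gives 5.5 nM, which is the lowest number seen. On that basis, the step from compound 3 to compound 4 is expected to lower the number well beyond the scatter, a 42-fold lower number from compound 3 to compound 4 (1.62 log units; beyond the scatter). Compound 4 is accordingly expected to give about 150 nM, with a plausible range from 15 nM to 1500 nM.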

Compound 4, half-maximal inhibitory concentration: 457 nM
The estimate for compound 4 lay 3.0-fold (0.48 log units) below the measured number; the measured number falls inside the stated range.
By their numbers in this assay, from the lowest: compound 1; then compound 4; then compound 3; then compound 2.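

In this assay, among the compounds shown here, the exchange on the sulfur gives a 14-fold lower number from compound 3 to compound 4 (1.14 log units; beyond the scatter), the first step in this set between two compounds that differ in one place, and it shows that the group on this sulfur alone can move the number well beyond the scatter while the shared core stays the same. The change is not a single clean variable, however: cyclohexyl and 4-methylbenzyl differ in whether the six-membered ring is aromatic, in their carbon count, and in the methyl group carried by the ring, so this one step cannot assign the gain to any one of these differences. No measurement shown here accounts for the size of the step.

The compounds shown leave open how plain benzyl, phenyl or cyclohexylmethyl on the same sulfur would compare, and cyclohexylmethyl in particular would keep the saturated ring while adding a carbon link to the sulfur. They also leave open whether the step would hold if an amine nitrogen or an ether oxygen stood in place of the sulfur.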